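Alkyl chain growth on the shared core

The compounds below may be only part of what the source reports. "The series", "measured", "known", "first", "only" and "open" are said of these compounds alone.

In a functional assay (Nicotiana tabacum) (a lower number here means a stronger inhibitor, a higher number a weaker inhibitor), compound 1 (`CCCNc1nc(SC)nc2ncccc12`) gives 270 nM and compound 2 (`CSc1nc(NCC(C)C)c2cccnc2n1`) gives 540 nM on the same core. Among the measured compounds shown here, the one measured step is a 2.0-fold higher number from compound 1 to compound 2 (0.30 log units; within the scatter) and leaves compound 2 level with compound 1. The change to compound 3 (`CCCCC(CC)CNc1nc(SC)nc2ncccc12`) is 1-ethylpentyl in place of isopropyl on a saturated chain carbon bound to a nitrogen on an aromatic ring. That single methyl step is a thin guide to so large a change, so the expected move toward a higher number is modest and uncertain (a 1.5-fold higher number from compound 2 to compound 3 (0.17 log units; within the scatter)). Compound 3 is expected at 800 nM with 200 nM to 3000 nM as the estimated range.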

Compound 3, half-maximal inhibitory concentration: 15900 nM
Estimate against measurement, compound 3: 20-fold (1.30 log units) below, and the stated range ends below it.
By their numbers in this assay, from the lowest: compounds 1 and 2 (each within the scatter of the next); then compound 3.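

In this assay, 1-ethylpentyl in place of isopropyl gives a 29-fold higher number from compound 2 to compound 3 (1.47 log units; beyond the scatter) and 1-ethylpentyl in place of ethyl gives a 59-fold higher number from compound 1 to compound 3 (1.77 log units; beyond the scatter) on the shared core. Among the compounds shown here, the position, on a saturated chain carbon bound to a nitrogen on an aromatic ring, therefore does respond to the alkyl group, which the single methyl step within the scatter between compound 1 and compound 2 did not reveal. Nothing available accounts for the size of these steps. Going by these compounds, whether the rise follows chain length or branching stays open. A straight hexyl chain or a cyclohexyl ring here would bear on that question.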